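Swapping the dichlorophenyl of compound 3 for a methylphenyl

This account rests on a few compounds, and the source may have more. Where it says the series, first, only, none or still open, it means among the compounds named here.

Within the data shown here, compound 3 `CC1CCN(Cc2ccc3nc(NC(=O)N/N=C/c4cn(Cc5ccc(Cl)cc5Cl)c5ccccc45)sc3c2)CC1` is the one compound here with a number: in a functional assay on MDA-MB-231 cells (Homo sapiens) for cytotoxicity, read by MTT assay, with a stated time of 72 h (a higher number here means a weaker inhibitor, a lower number a stronger inhibitor), compound 3 gives 3140 nM. Two related compounds, compound 1 `CN(C)Cc1ccc2nc(NC(=O)N/N=C3\C(=O)Nc4ccc(F)cc43)sc2c1` and compound 2 `CCN(CC)Cc1ccc2nc(NC(=O)N/N=C3\C(=O)Nc4ccc(F)cc43)sc2c1`, share the urea-linked core but carry no reported result: in this assay compound 1 gives "not determined" (no result reported), and compound 2 gives "not determined" (no result reported). Compound 3 therefore stands alone and cannot be placed as stronger or weaker than anything else.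

Compound 4 `Cc1ccc(Cn2cc(/C=N/NC(=O)Nc3nc4ccc(CN5CCC(C)CC5)cc4s3)c3ccccc32)cc1` differs from compound 3 in one place: 4-methylphenyl in place of 2,4-dichlorophenyl on a saturated chain carbon bound to an aromatic nitrogen.

Among the measured compounds shown here, no measured pair shows what such a swap does, so the expectation rests on compound 3 alone. The step from compound 3 to compound 4 is expected to be small, a slight weakening that stays within the scatter, as a 1.4-fold higher number from compound 3 to compound 4 (0.16 log units; within the scatter). Compound 4 is therefore estimated at 4500 nM, with a likely range from 1500 nM to 13000 nM.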

Compound 4, half-maximal inhibitory concentration: 1140 nM
Beside the measured number, compound 4's estimate is 3.9-fold (0.60 log units) above it, and the stated range ends above it.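

In this assay, the group on a saturated chain carbon bound to an aromatic nitrogen proves able to shift the result: 4-methylphenyl in place of 2,4-dichlorophenyl gives a 2.8-fold lower number from compound 3 to compound 4 (0.44 log units; beyond the scatter) and so a stronger inhibitor. Chlorine on this ring is therefore not required for cytotoxicity in these cells. No measurement at hand accounts for this step.

Going by these compounds, the swap makes two changes at once, so it remains open whether losing the chlorines or gaining the methyl matters more. A plain benzyl group here would help separate the two.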